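This account rests on a few compounds, and the source may have more. Where it says the series, first, only, none or still open, it means among the compounds named here.

In a functional assay on the whole organism with Rattus norvegicus as the target (on this read-out lower numbers stand for an effect already at smaller amounts and higher numbers for an effect only at larger amounts of compound), compound 1 `CC(C)(C)Oc1ccc2nc(N)sc2c1` gives > 10 mg/kg, which is a limit of the assay and not a number.
In this assay compound 2 `Nc1nc2ccc(OC(F)(F)C(F)F)cc2s1` gives 8.5 mg/kg.
In this assay compound 3 `N=c1sc2cc(OC(F)(F)F)ccc2n1Cc1ccccc1` gives > 10 mg/kg, again a limit of the assay rather than a number.

Compound 3 thus stands at the upper edge of what the measurements shown can resolve; only a limit is known for it, and the limit of > 10 mg/kg in this assay, at which 2 of the 3 values shown sit, marks where it sits. Going by the values given here, no pair of measured compounds differs in a single place, so no measured step is available to guide the next one. Compound 4 `CCSCCn1c(=N)sc2cc(OC(F)(F)F)ccc21` is the untested compound, and it differs from compound 3 in one way: (ethylsulfanyl)methyl in place of phenyl on a saturated chain carbon bound to an aromatic nitrogen.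

With compound 3 known only as a limit, the estimate for compound 4 can only rest on that limit. Compound 4 is expected to give about 10 mg/kg, within a range from 5 mg/kg to 20 mg/kg. The step of a number no higher from compound 3 to compound 4 (the limit leaves the size open) is expected to be none beyond the usual scatter, and a second limit rather than a number is the likelier outcome.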

Compound 4, dose for half-maximal effect: 2.2 mg/kg
For compound 4 the middle estimate is 4.5-fold (0.66 log units) above the measured one; measured number below the stated range.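

In this assay, going by these compounds alone, the place on a saturated chain carbon bound to an aromatic nitrogen proves responsive, since (ethylsulfanyl)methyl in place of phenyl gives an at least 4.5-fold lower number from compound 3 to compound 4 (0.65 log units; beyond the scatter) and so the first single-place comparison. The earlier compounds shown here could not show this, as no two of them differed in one place. From the compounds shown here alone, compound 4 gives this position a number, whereas compound 3 remains a limit of the assay, so the full size of the step stays unknown: the limit of > 10 mg/kg in this assay, at which 2 of the 4 values shown sit.

The compounds shown leave open whether the sulfur or the loss of the phenyl ring matters, as both change in one step. A 2-ethoxyethyl group, a plain butyl chain or an amine at the end of the chain at this place would help to separate the two.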